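The source may report more compounds than this note shows. Statements on the series, on what has been measured and on what is new or still open speak of the compounds shown alone.

Working notes on the series.

Compound 1 `Cc1ccc(CNC(=O)c2[nH]cnc2C(=O)Nc2ccc(Cl)c(Cl)c2)cc1` and compound 2 `C[C@@H](NC(=O)c1[nH]cnc1C(=O)Nc1ccc(Cl)c(Cl)c1)c1ccccc1` share one core and differ in the group on the amide-type nitrogen. In a functional assay on HL-60 cells (Homo sapiens), with a stated time of 2 days (on this read-out lower numbers stand for stronger inhibition and higher numbers for weaker inhibition), compound 1 gives 21400 nM, and compound 2 gives 8800 nM. The step is a 2.4-fold lower number from compound 1 to compound 2 (0.39 log units; beyond the scatter). On the numbers shown compound 2 therefore stands lowest of the two, with compound 1 as its only neighbour.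

Compound 3 `C[C@H](NC(=O)c1[nH]cnc1C(=O)Nc1ccc(Cl)c(Cl)c1)c1ccccc1` is not yet measured. Relative to compound 2 the change is the two compounds have the same atoms and bonds and differ only in configuration as drawn: 1 of 1 stereo elements differ; a stereocentre at a saturated chain carbon is drawn R in compound 2 and S in compound 3; nothing leaves and nothing enters. Among the compounds with values here, none of the measured steps alters configuration alone, so no step bears directly on this change; the only step at hand, from compound 1 to compound 2, exchanged the whole group on that nitrogen. The size and direction of the step in this assay are therefore open. As a working expectation, the step from compound 2 to compound 3 is taken as a 1.7-fold higher number from compound 2 to compound 3 (0.23 log units; within the scatter), and compound 3 is estimated at 15000 nM, within 4000 nM to 60000 nM.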

Compound 3, half-maximal inhibitory concentration: 9200 nM
The estimate for compound 3 lay 1.6-fold (0.21 log units) above the measured number; measured number inside the range.
By their numbers in this assay, from the lowest: compounds 2 and 3 (each within the scatter of the next); then compound 1.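

In this assay the step is a 1.0-fold higher number from compound 2 to compound 3 (0.02 log units; within the scatter), so the two drawn configurations of the 1-phenylethyl group cannot be told apart on this read-out. The change from the 4-methylbenzyl group holds for either configuration: the step is a 2.3-fold lower number from compound 1 to compound 3 (0.37 log units; beyond the scatter), which sits beside a 2.4-fold lower number from compound 1 to compound 2 (0.39 log units; beyond the scatter) as a modest change of similar size. Configuration is the only variable in the pair, so this comparison is a clean one: the fact that compounds 2 and 3 differ only in the configuration as drawn

The change from 4-methylbenzyl to 1-phenylethyl moves two methyl features at once, and the compounds shown do not separate them; an unsubstituted benzyl group on the same nitrogen would do so. Also open, as far as these compounds go, is whether configuration stays without consequence once the methyl of the 1-phenylethyl group gives way to a longer chain, such as ethyl, or to a carboxylic acid.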